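This account rests on a few compounds, and the source may have more. Where it says the series, first, only, none or still open, it means among the compounds named here.

Measured compounds in a functional assay for inhibition, with Homo sapiens as the target; a lower number here means a stronger inhibitor, a higher number a weaker inhibitor:
compound 1 `CCCc1nc(C)c2cnnc(O)n12` — 56800 nM
compound 2 `CCCc1nc(C)c2cnnc(SC)n12` — > 48000 nM, a limit of the assay
compound 3 `CCCc1nc(C)c2c(-c3ccccc3)nnc(O)n12` — > 48000 nM, a limit of the assay

Compound 1 is the only one of the three with a number in this assay; the other two sit at a limit. Because of the limit of > 48000 nM in this assay, at which 2 of the 3 values shown sit, the steps from compound 1 to compound 2 and from compound 1 to compound 3 cannot be sized: a step that the limit leaves unreadable from compound 1 to compound 2 and a step that the limit leaves unreadable from compound 1 to compound 3 are both unreadable. Compound 4 `Cc1nc(C(C)C)n2c(O)nncc12` is unmeasured; it differs from compound 1 by isopropyl in place of propyl on an aromatic carbon. Among the measured compounds shown here, neither measured step touches this position or this kind of change, so no measured step bears on it. With nothing to point toward a shift, the expected step from compound 1 to compound 4 in this assay is a 1.0-fold lower number from compound 1 to compound 4 (0.01 log units; within the scatter), no larger than the scatter. Compound 4 is therefore estimated at 55000 nM, within 20000 nM to 150000 nM, and a limit rather than a number is well possible.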

Compound 4, half-maximal inhibitory concentration: > 48000 nM
Compound 4 ended at the assay's limit (the forecaster's own chance of this, stated with the estimate: 50%); the middle value lies beyond the limit too.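

In this assay compound 4 gives > 48000 nM, which is a limit and not a number. No size can therefore be read for the change from compound 1 to compound 4, because of this: the limit of > 48000 nM in this assay, at which 3 of the 4 values shown sit. The compounds shown leave open whether any change to the core of compound 1 gives a stronger inhibitor.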